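Piperazine for mesylate on the shared core

A few compounds are considered here, and "the series" means these few. Any claim that something is new, unique, unknown or untested is made for them only; others in the source may bear on it.

In a functional assay on HCT-116 cells (Homo sapiens) for cytotoxicity, read by MTT assay, with a stated time of 72 h (on this read-out higher numbers stand for weaker inhibition and lower numbers for stronger inhibition), compound 1 `CS(=O)(=O)Oc1c(C(=O)NCc2ccc(F)cc2)nc(Br)c2cccnc12` gives > 20000 nM, which is a limit of the assay rather than a number. Compound 2 `COC(=O)c1nc(Br)c2cccnc2c1N[C@H]1CC[C@H](N)CC1` has "not determined" (no result reported) in this assay. For the measured compounds named here, compound 1 therefore sits at the limit of > 20000 nM in this assay, at which 1 of the 2 values shown sits, and no step between measured compounds is known. Compound 3 `O=C(NCc1ccc(F)cc1)c1nc(Br)c2cccnc2c1N1CCNCC1` carries piperazin-1-yl in place of (methylsulfonyl)oxy on an aromatic carbon. Going by the values given here, with no measured step to lean on, no change beyond the scatter is expected from compound 1 to compound 3, so compound 3 is expected to give 15000 nM, between 3000 nM and 40000 nM, the step being an at least 1.3-fold lower number from compound 1 to compound 3 (0.12 log units; that floor lies within the scatter).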

Compound 3, half-maximal inhibitory concentration: > 10000 nM
Compound 3: a limit, no number (the forecaster's own chance of this, stated with the estimate: 60%); the middle value lies beyond the limit too.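

In this assay, for the compounds shown here, compound 1 and compound 3 both give limits rather than numbers, and no step between them can be read. Still open, going by these compounds, is whether piperazin-1-yl in place of (methylsulfonyl)oxy on the shared core changes the cytotoxicity at all.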